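This account rests on a few compounds, and the source may have more. Where it says the series, first, only, none or still open, it means among the compounds named here.

Three compounds built on a shared core, differing only in the group on one aromatic ring, have been measured in a functional assay on MCF7 cells (Homo sapiens) for inhibition, read by sulforhodamine B assay, with a stated time of 72 h; on this read-out higher numbers stand for weaker inhibition and lower numbers for stronger inhibition. Compound 1 `CC(c1ccc(-c2ccccc2)c(F)c1)c1nnc2n1N=C(c1ccc(Cl)cc1)CS2` gives 8700 nM. Compound 2 `COc1ccc(C2=Nn3c(nnc3C(C)c3ccc(-c4ccccc4)c(F)c3)SC2)cc1` gives 2600 nM, and the change a 3.3-fold lower number from compound 1 to compound 2 (0.52 log units; beyond the scatter). Compound 3 `CC(c1ccc(-c2ccccc2)c(F)c1)c1nnc2n1N=C(c1ccc([N+](=O)[O-])cc1)CS2` gives 7800 nM; the change a 1.1-fold lower number from compound 1 to compound 3 (0.05 log units; within the scatter), while the change a 3.0-fold higher number from compound 2 to compound 3 (0.48 log units; beyond the scatter). On these numbers compound 3 stands second highest of the three, close to compound 1 and well apart from compound 2.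

Compound 4 `CC(c1ccc(-c2ccccc2)c(F)c1)c1nnc2n1N=C(c1ccc(F)cc1)CS2` is the next one to be measured. Its difference from compound 3: fluoro in place of nitro on an aromatic carbon. For the measured compounds named here, the step that bears most directly on it is the one from compound 1 to compound 3, where swapping chloro for nitro stayed within the scatter; only methoxy, in compound 2, moved the number clearly. A single fluorine is expected to behave more like chloro than like methoxy, so the step of a 1.0-fold lower number from compound 3 to compound 4 (0.02 log units; within the scatter) is expected to stay within the scatter. For compound 4 the expected value in this assay is 7500 nM, between 3000 nM and 19000 nM.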

Compound 4, half-maximal inhibitory concentration: 8100 nM
Estimate against measurement, compound 4: 1.1-fold (0.03 log units) below; the measured number falls inside the stated range.
By their numbers in this assay, from the lowest: compound 2; then compounds 3, 4 and 1 (each within the scatter of the next).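

Fluoro has one heavy atom and nitro has three, yet on this aromatic carbon, para to a large group, replacing nitro with fluoro in this assay gives a 1.0-fold higher number from compound 3 to compound 4 (0.02 log units; within the scatter). Replacing chloro with fluoro is just as small, with a 1.1-fold lower number from compound 1 to compound 4 (0.03 log units; within the scatter), so chloro, nitro and fluoro cannot be told apart here, while methoxy still stands apart, with a 3.1-fold higher number from compound 2 to compound 4 (0.49 log units; beyond the scatter). No supporting data offer a cause for this separation.

As far as these compounds go, it remains open whether the lower number of compound 2 is particular to methoxy or would also appear with a hydroxyl, an amine or a longer chain such as ethoxy. It is also unknown how a carboxylic acid would read at this same place.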